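Amide aryl swap on the shared core: methoxyphenyl to nitrophenyl

A few compounds are considered here, and "the series" means these few. Any claim that something is new, unique, unknown or untested is made for them only; others in the source may bear on it.

Compound 1 `CC(=O)N(C)c1ccc2[nH]c(-c3n[nH]c4ccccc34)cc2n1` and compound 2 `COc1cccc(C(=O)N(C)c2ccc3[nH]c(-c4n[nH]c5ccccc45)cc3n2)c1` share one core and differ only at the carbonyl carbon. In a functional assay on HCT-116 cells (Homo sapiens) for antiproliferative activity, read by MTT assay, with a stated time of 72 h (a lower number here means a stronger inhibitor, a higher number a weaker inhibitor), compound 1 gives 14800 nM. In this assay compound 2 gives 14200 nM, which sits alongside compound 1 within the scatter; the step of a 1.0-fold lower number from compound 1 to compound 2 (0.02 log units; within the scatter) shows that. Compound 3 `CN(C(=O)c1ccc([N+](=O)[O-])cc1)c1ccc2[nH]c(-c3n[nH]c4ccccc34)cc2n1` carries the change (4-nitrophenyl in place of 3-methoxyphenyl on a carbonyl carbon). Within the data shown here, only the step from compound 1 to compound 2 bears on it, and that step was flat, so no step beyond the scatter is expected here, a 1.0-fold lower number from compound 2 to compound 3 (0.01 log units; within the scatter). Compound 3 is expected at 14000 nM, within 6000 nM to 35000 nM.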

Compound 3, half-maximal inhibitory concentration: 19900 nM
Beside the measured number, compound 3's estimate is 1.4-fold (0.15 log units) below it; measured number inside the range.
By their numbers in this assay, from the lowest: compounds 2, 1 and 3 (each within the scatter of the next).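

At the carbonyl carbon, 4-nitrophenyl in place of 3-methoxyphenyl leaves the read-out in this assay within the scatter (a 1.4-fold higher number from compound 2 to compound 3 (0.15 log units; within the scatter)), and the same holds for 4-nitrophenyl in place of methyl (a 1.3-fold higher number from compound 1 to compound 3 (0.13 log units; within the scatter)). The flat result at this position now extends to a second aryl group, so methyl, 3-methoxyphenyl and 4-nitrophenyl cannot be told apart here. No evidence bears on why this position stays flat. Open, on these data alone, is whether an amine or a carboxylic acid on the carbonyl carbon would give a step beyond the scatter.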